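This account rests on a few compounds, and the source may have more. Where it says the series, first, only, none or still open, it means among the compounds named here.

Compound 1, `O=c1[nH]c(=O)n([C@@H]2O[C@H](CO)[C@@H](O)[C@H]2O)cc1C#CC1CCCCC1`: 36800 nM
Compound 2, `O=c1[nH]cc(C#CC2CCCCC2)c(=O)[nH]1`: 62800 nM

Both numbers come from an ADME assay on MRC5 cells (Homo sapiens) for cytotoxicity, read by MTT assay; on this read-out lower numbers stand for higher toxicity in this test and higher numbers for lower toxicity in this test. Compound 1 gives the lowest of the two numbers, with compound 2 the nearest at a higher number; that gap lies within the scatter, so the two compounds cannot be told apart on this read-out. Both numbers sit high, which means weak toxicity in this assay for either compound.

Compound 3, `O=c1[nH]c(=O)n([C@@H]2O[C@H](CO)[C@@H](O)[C@H]2O)cc1C#CC1CC1`, has not been measured. It differs from compound 1 in one place: cyclopropyl in place of cyclohexyl on a triple-bonded carbon. Going by the values given here, no step between measured compounds shows what a change of this kind does on this read-out, so the only guide is where compound 1 and compound 2 stand. With both of them weakly toxic and indistinguishable within the scatter, no step beyond the scatter is expected in this assay for the move to compound 3, in either direction. Compound 3 is therefore expected at 45000 nM, within 20000 nM to 100000 nM. The expected step of a 1.2-fold higher number from compound 1 to compound 3 (0.09 log units; within the scatter) thus stays within the scatter.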

Compound 3, half-maximal cytotoxic concentration: 24200 nM
For compound 3 the middle estimate is 1.9-fold (0.27 log units) above the measured one; measured number inside the range.
By their numbers in this assay, from the lowest: compounds 3, 1 and 2 (each within the scatter of the next, the first and the last beyond it).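

Going by these compounds alone, on the triple-bonded carbon of the core of compound 1, cyclopropyl in place of cyclohexyl gives a 1.5-fold lower number from compound 1 to compound 3 (0.18 log units; within the scatter) in this assay, the first direct reading of a change at this position. Cyclohexyl and cyclopropyl are both non-aromatic rings of carbon only, with no hydrogen-bond donors or acceptors and no net charge, so this pair isolates ring size among these all-carbon groups, and a ring of very different size leaves no step that can be resolved from the scatter. No measurement of another property bears on this step, so the result stays a plain reading of toxicity in this test.

From the compounds shown here alone, whether a different kind of group on the triple-bonded carbon, such as an amine, a carboxylic acid or a longer alkyl chain, would give a step beyond the scatter remains open. Also open is how the change from cyclohexyl to cyclopropyl reads on the core of compound 2, since the only step shown is the one on the core of compound 1.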